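A few compounds are considered here, and "the series" means these few. Any claim that something is new, unique, unknown or untested is made for them only; others in the source may bear on it.

Measured so far:
- compound 1 `CN(c1ncco1)c1cnc(NCc2c(F)ccc3c2CCO3)n2cnnc12`: 67000 nM
- compound 2 `Cc1nccn1-c1cnc(NCc2c(F)ccc3c2CCO3)c2cn[nH]c(=O)c12`: 7000 nM
- compound 3 `Cc1ncccc1-c1cnc(NCc2c(F)ccc3c2CCO3)c2cn[nH]c(=O)c12`: < 2000 nM

In a physicochemical assay for solubility, read by LC-MS, in phosphate buffer, with a stated time of 24 h, at pH 7.4 (on this read-out higher numbers stand for higher solubility and lower numbers for lower solubility), compound 1 gives the highest of the two numbers; the nearest, compound 2, gives a lower one. The value of compound 3 is a limit of this assay, not a number, so its exact position is open (the limit of < 2000 nM in this assay, at which 1 of the 3 values shown sits). Within the data shown here, the one step that can be sized, an at least 3.5-fold lower number from compound 2 to compound 3 (0.54 log units; beyond the scatter), concerns a change on a different core from that of compound 1 and does not touch the group that is exchanged here.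

Compound 4 `O=C(Nc1cnc(NCc2c(F)ccc3c2CCO3)n2cnnc12)c1cccnc1` keeps the core of compound 1 and differs from it in one place: ((pyridin-3-yl)carbonyl)amino in place of methyl(1,3-oxazol-2-yl)amino on an aromatic carbon. Among the measured compounds shown here, no measured step bears on this exchange, so the expectation rests on the starting value of compound 1 alone. A modest drop is expected, a 2.7-fold lower number from compound 1 to compound 4 (0.43 log units; beyond the scatter), with wide uncertainty in both directions. For compound 4 the estimated value in this assay is 25000 nM, expected to fall between 6000 nM and 80000 nM.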

Compound 4, solubility: 12000 nM
Beside the measured number, compound 4's estimate is 2.1-fold (0.32 log units) above it; the range from low to high includes it.
By their numbers in this assay, from the lowest: compounds 2 and 4 (each within the scatter of the next); then compound 1. At a limit, below all of these: compound 3.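

In this assay, among these compounds, this is the first measured exchange at this position on the shared core: with ((pyridin-3-yl)carbonyl)amino in place of methyl(1,3-oxazol-2-yl)amino on an aromatic carbon, the result is a 5.6-fold lower number from compound 1 to compound 4 (0.75 log units; beyond the scatter). The read-out therefore does respond to what this position carries, but the two groups differ in several ways at once, including ring size, heavy-atom count and the hydrogen-bond donor of the entering group, so one step cannot separate these differences. Nothing measured here gives a reason for the step.

The compounds shown leave open how a plain amine, a carboxylic acid or a benzoylamino group, with a phenyl ring in place of the pyridin-3-yl, would read at this position on the shared core. They also leave open whether the ((pyridin-3-yl)carbonyl)amino group would give a step of similar size on the different core of compound 2 and compound 3.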